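The source may report more compounds than this note shows. Statements on the series, on what has been measured and on what is new or still open speak of the compounds shown alone.

Among the measured compounds shown here, in a functional assay on MT4 cells (Homo sapiens) for cytotoxicity, read by MTT assay (a higher number here means that more compound is tolerated, a lower number that less compound is tolerated), compound 1 `Cc1cc(C)cc(S(=O)(=O)c2c(C(=O)NCC(N)=O)[nH]c3ccc(Cl)cc23)c1` gives 45 uM, the only measured number so far. Compound 2 `Cc1cc(C)cc(S(=O)(=O)c2c(C(=O)NNC(C)C)[nH]c3ccc(Cl)cc23)c1` gives > 100 uM, which is a limit of the assay. Compound 3 `CC(=O)NNC(=O)c1[nH]c2ccc(Cl)cc2c1S(=O)(=O)c1cc(C)cc(C)c1` gives > 100 uM, which is also a limit and not a number. Compound 3 thus stands at the limit of > 100 uM in this assay, at which 2 of the 3 values shown sit.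

Compound 4 `Cc1cc(C)cc(S(=O)(=O)c2c(C(=O)NNC(=O)NN)[nH]c3ccc(Cl)cc23)c1` differs from compound 3 by aminoamino in place of methyl on a carbonyl carbon, with aminoamino in place of methyl on a carbonyl carbon. For the measured compounds named here, no measured step makes this exact change. The nearest evidence comes from changes on the amide-type nitrogen: an at least 2.2-fold higher number from compound 1 to compound 2 (0.34 log units; beyond the scatter), and an at least 2.2-fold higher number from compound 1 to compound 3 (0.34 log units; beyond the scatter). Both are at least modest and beyond the scatter, while a step that the two limits leave unreadable from compound 2 to compound 3 cannot be sized. Compound 1 at 45 uM shows that lower values do occur among these compounds, so a modest fall in this assay cannot be ruled out. No step beyond the scatter is the likeliest outcome, and the expected step is an at least 1.1-fold lower number from compound 3 to compound 4 (0.04 log units; that floor lies within the scatter). For compound 4 the estimated value is 90 uM, within an expected range of 35 uM to 130 uM.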

Compound 4, half-maximal toxic concentration: > 100 uM
Compound 4: only a limit was reported; the forecaster's own chance of this, stated with the estimate: 60%; middle value at least 1.1-fold (0.04 log units) away from the limit.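

In this assay compound 4 gives > 100 uM, which is a limit of the assay and not a number. Among the compounds shown here, the steps to this compound from compound 2 and from compound 3 cannot be read, so the change from methyl to aminoamino on a carbonyl carbon has no measurable size here, and the one readable step is an at least 2.2-fold higher number from compound 1 to compound 4 (0.34 log units; beyond the scatter). The new group on this carbonyl carbon therefore brings no measured number into the assay, and compound 4 joins compound 2 and compound 3 at the same limit: the limit of > 100 uM in this assay, at which 3 of the 4 values shown sit.

From the compounds shown here alone, how far compound 2, compound 3 and compound 4 each lie past that limit remains open, so they cannot be ordered. Also open, going by these compounds, is whether an amine, a carboxylic acid or a longer alkyl chain on this carbonyl carbon would stay at the limit or give a measured number, as compound 1 does.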